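Ether chain extension from compound 2 to compound 3

The source may report more compounds than this note shows. Statements on the series, on what has been measured and on what is new or still open speak of the compounds shown alone.

Compound 1 `Nc1ncc(Cc2ccccc2O)c(N)n1` carries a hydroxyl on the aromatic ring; in an assay for inhibition of Dihydrofolate reductase (Gallus gallus) (on this read-out higher numbers stand for weaker inhibition and lower numbers for stronger inhibition), compound 1 gives 89100 nM. Compound 2 `COc1ccccc1Cc1cnc(N)nc1N` has the methyl ether in its place, and in this assay compound 2 gives 28800 nM. For the measured compounds named here, the step of a 3.1-fold lower number from compound 1 to compound 2 (0.49 log units; beyond the scatter) is the only measured step in the set so far. Compound 2 therefore stands with the lower of the two numbers, compound 1 being the nearest and only other point.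

Compound 3 `CCOc1ccccc1Cc1cnc(N)nc1N` lengthens the ether: methyl in place of hydrogen on a saturated chain carbon bound to an oxygen on an aromatic ring. Going by the values given here, the single measured step bears on it only loosely, since it also altered the group on the oxygen of the aromatic ring, and its size, a 3.1-fold lower number from compound 1 to compound 2 (0.49 log units; beyond the scatter), was modest. Among the compounds with values here, no measured pair shows what a further carbon on the chain does. A small further lowering, or a change within the scatter, is expected. Compound 3 is estimated in this assay at 18000 nM, with a range of 6000 nM to 60000 nM. This corresponds to an expected step of a 1.6-fold lower number from compound 2 to compound 3 (0.20 log units; within the scatter).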

Compound 3, inhibition constant: 24500 nM
The estimate for compound 3 lay 1.4-fold (0.13 log units) below the measured number; the range from low to high includes it.
By their numbers in this assay, from the lowest: compounds 3 and 2 (each within the scatter of the next); then compound 1.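

In this assay, for the compounds shown here, the further methyl on the saturated chain carbon bound to the oxygen gives a 1.2-fold lower number from compound 2 to compound 3 (0.07 log units; within the scatter), so methoxy and ethoxy cannot be told apart at this position, something the single earlier step could not show. Against the hydroxyl of compound 1, ethyl in place of hydrogen on the oxygen gives a 3.6-fold lower number from compound 1 to compound 3 (0.56 log units; beyond the scatter), which like a 3.1-fold lower number from compound 1 to compound 2 (0.49 log units; beyond the scatter) lies beyond the scatter, so among these three compounds the only readable difference is between the free hydroxyl and either ether, not between the two ethers. No supporting data bear on why the read-out responds in this way.

From the compounds shown here alone, it remains open whether the insensitivity to the added methyl holds for a longer chain such as propyl or for a branched group such as isopropyl on the same oxygen. Also open is how an amine in place of the ether oxygen would read in this assay, since the compounds shown carry only hydrogen, methyl and ethyl on that oxygen.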